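The compounds below may be only part of what the source reports. "The series", "measured", "known", "first", "only" and "open" are said of these compounds alone.

Working notes on the series. The three measured compounds share one core and differ only in the group carried on the sulfur. Compound 1 `Cn1c(-c2ccc(NC(=O)CSc3nc4cc(Cl)ccc4o3)cc2)nc(-c2ccccc2)c1-c1ccccc1` gives 11.9% in a functional assay on HT-29 cells (Homo sapiens) for cytotoxicity, read by MTT assay, with a stated time of 24 h, tested at 0.64 ug/mL; on this read-out higher numbers stand for a stronger effect at the one concentration tested and lower numbers for a weaker effect. Compound 2 `Cc1ccc2oc(SCC(=O)Nc3ccc(-c4nc(-c5ccccc5)c(-c5ccccc5)n4C)cc3)nc2c1` gives 11% in this assay, and compound 3 `Cn1c(-c2ccc(NC(=O)CSC3=NCCS3)cc2)nc(-c2ccccc2)c1-c1ccccc1` gives 16.8% in this assay. Compound 2 holds the lowest of the three numbers, yet neither of the others separates from it: a number 0.9 percentage points lower from compound 1 to compound 2 (within the scatter), and a number 5.8 percentage points higher from compound 2 to compound 3 (within the scatter). The remaining step, a number 4.9 percentage points higher from compound 1 to compound 3 (within the scatter), is equally flat, so across the three measured compounds no exchange on the sulfur has produced a difference beyond the scatter.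

Compound 4 `Cn1ccnc1SCC(=O)Nc1ccc(-c2nc(-c3ccccc3)c(-c3ccccc3)n2C)cc1` has not yet been measured. Relative to compound 2 the change is 1-methyl-1H-imidazol-2-yl in place of 5-methyl-1,3-benzoxazol-2-yl on a sulfur. For the measured compounds named here, the steps that bear on this are the two in which the larger group on the sulfur was exchanged for a smaller ring, a number 5.8 percentage points higher from compound 2 to compound 3 (within the scatter) and a number 4.9 percentage points higher from compound 1 to compound 3 (within the scatter); both stayed within the scatter, so for this exchange too no step beyond the scatter is expected in this assay. Compound 4 is therefore estimated at 14%, with a range from 6% to 22%. The step this estimate implies is a number 3 percentage points higher from compound 2 to compound 4 (within the scatter).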

Compound 4, a percentage reported as activity, at one concentration (the size of the read-out at that concentration, not a potency): 13.6%
Beside the measured number, compound 4's estimate is 0.4 percentage points above it; the range from low to high includes it.
By their numbers in this assay, from the lowest: compounds 2, 1, 4 and 3 (each within the scatter of the next).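

In this assay, the single aromatic ring of 1-methyl-1H-imidazol-2-yl stands in for the two-ring benzoxazole groups with a number 2.6 percentage points higher from compound 2 to compound 4 (within the scatter) and a number 1.7 percentage points higher from compound 1 to compound 4 (within the scatter), so losing the six-membered aromatic ring of carbon only from the group on the sulfur, while keeping a five-membered aromatic ring with 2 hetero atoms, does not separate the compounds. For the compounds shown here, the new compound also allows the first comparison of two five-membered rings on this sulfur, one aromatic and one non-aromatic, and that exchange is equally flat, with a number 3.2 percentage points lower from compound 3 to compound 4 (within the scatter). No measurement is available that would account for this flatness at the position.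

The compounds shown say nothing about a group on the sulfur that has no ring, such as a short alkyl chain, or about a ring carrying an amine or a carboxylic acid. As far as these compounds go, all values also come from one concentration, so whether the four compounds would separate at other concentrations or with changes elsewhere on the shared core remains open.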